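The source may report more compounds than this note shows. Statements on the series, on what has been measured and on what is new or still open speak of the compounds shown alone.

Working notes on the series. The shared core carries a primary amine and an aminoalkyl chain ending in an aromatic ring. Compound 1 `Nc1nc(NCCCc2ccccc2)nc(-c2ccccc2CO)n1` gives 5.22 in a functional assay on cells for positive allosteric modulation of G-protein coupled receptor 68 (Homo sapiens), read by a luciferase reporter and cAMP accumulation, with a stated time of 30 min, at pH 6.8 and pH 8.3, in the presence of a further agent that is not named here; a lower number here means a less potent compound, a higher number a more potent compound, by a factor of ten per unit of this negative logarithm. Among the measured compounds shown here, compound 2 `Nc1nc(NCCCCc2ccccc2)nc(-c2ccccc2CO)n1` gives 5.52 and holds the highest of the three numbers so far, though the step of a number 0.30 log units higher from compound 1 to compound 2 (within the scatter) lies within the scatter, so compounds 1 and 2 are not separated; only compound 3 `Nc1nc(NCCCc2ccc(Oc3ccccc3)cc2)nc(-c2ccccc2CO)n1`, which gives 4.67, stands clearly apart from compound 2.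

The next compound, compound 4 `Nc1nc(NCCCCc2ccc(Oc3ccccc3)cc2)nc(-c2ccccc2CO)n1`, differs from compound 2 by phenoxy in place of hydrogen on an aromatic carbon: the incoming phenoxy brings one six-membered aromatic ring of carbon only with one hydrogen-bond acceptor and no net charge, and it sits on an aromatic carbon of a six-membered aromatic ring of carbon only, para to a large group. The same change has been made once already, on the shorter chain: the step of a number 0.55 log units lower from compound 1 to compound 3 (beyond the scatter) was beyond the scatter and modest in size. That step bears directly on the present one, and a drop of similar size in this assay is therefore expected, giving an expected step of a number 0.55 log units lower from compound 2 to compound 4 (beyond the scatter). Compound 4 is accordingly estimated at 4.97, with a range from 4.5 to 5.4.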

Compound 4, negative logarithm of the antagonist equilibrium constant: 4.81
Beside the measured number, compound 4's estimate is 0.16 log units above it, and the stated range covers the measured number.
By their numbers in this assay, from the lowest: compounds 3 and 4 (each within the scatter of the next); then compounds 1 and 2 (each within the scatter of the next).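

On the longer chain, phenoxy in place of hydrogen on an aromatic carbon, para to a large group, again lowers the number in this assay, and the step reads a number 0.71 log units lower from compound 2 to compound 4 (beyond the scatter). The drop therefore no longer rests on a single pair of compounds, and it appears on both chain lengths with similar size: the same change on two cores in this assay, a number 0.55 log units lower (beyond the scatter) from compound 1 to compound 3 and a number 0.71 log units lower (beyond the scatter) from compound 2 to compound 4, 0.16 log units apart, within the scatter of two such steps The chain length that left compound 1 and compound 2 unseparated also leaves the phenoxy pair close, with compound 3 at 4.67 and compound 4 at 4.81, within the scatter of each other.

The compounds shown leave open whether a smaller group at this position, such as methoxy or a chlorine atom, would keep the number of compound 2, and whether the drop follows the ether oxygen or the added ring, which a phenyl or benzyl group in the same place would help to separate. Also open, from the compounds shown here alone, is how a longer chain than that of compound 2, or an amine on the terminal ring, would read in this assay.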